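A Methyl on the Amine Nitrogen of Compound 2

A few compounds are considered here, and "the series" means these few. Any claim that something is new, unique, unknown or untested is made for them only; others in the source may bear on it.

The numbers so far come from a physicochemical assay for solubility, at pH 7.4; on this read-out higher numbers stand for higher solubility and lower numbers for lower solubility:

compound 1, `CNC1CN(c2c(F)cc3c(=O)c(C(=O)O)cn(C4CC4)c3c2F)C1`, gives 1.7 ug/mL
compound 2, `CN[C@H]1CN(c2c(F)cc3c(=O)c(C(=O)O)cn(C4CC4)c3c2F)[C@@H]1C`, gives 13.1 ug/mL
compound 3, `CC1(N)CN(c2c(F)cc3c(=O)c(C(=O)O)cn(C4CC4)c3c2F)C1`, gives 0.8 ug/mL; 15.3 ug/mL (2 entries)

Compound 2 stands highest of the two single numbers; its nearest neighbour is compound 1, and that gap, a 7.7-fold higher number from compound 1 to compound 2 (0.89 log units; beyond the scatter), lies beyond the scatter. Compound 3 offers no single number to rank against, because its two entries spread far apart, (the several entries of compound 3 in this assay, 0.8 ug/mL; 15.3 ug/mL (2 entries)).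

Compound 4, `C[C@@H]1[C@@H](N(C)C)CN1c1c(F)cc2c(=O)c(C(=O)O)cn(C3CC3)c2c1F`, differs from compound 2 by one change: methyl in place of hydrogen on an amine nitrogen. Going by the values given here, only one measured step exists, a 7.7-fold higher number from compound 1 to compound 2 (0.89 log units; beyond the scatter), and it concerns a methyl on a saturated ring carbon rather than on the amine nitrogen, so it bears on the present change only loosely. The wide pair of entries for compound 3 shows how much a single number of this kind can move on repetition. Among the compounds with values here, there is thus no measured step that points in a clear direction for a methyl entering on the amine nitrogen, and the expectation is a step of no more than the scatter, in either direction.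

Compound 4 is therefore estimated at 10 ug/mL, with a range from 3 ug/mL to 40 ug/mL. The step of a 1.3-fold lower number from compound 2 to compound 4 (0.12 log units; within the scatter) is expected to stay within the scatter.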

Compound 4, solubility: 97.1 ug/mL
For compound 4 the middle estimate is 9.7-fold (0.99 log units) below the measured one; the whole stated range lies below it.
By their numbers in this assay, from the lowest: compound 1; then compound 2; then compound 4.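

In this assay, the amine nitrogen proves to be a place where one added methyl moves the number beyond the scatter: a 7.4-fold higher number from compound 2 to compound 4 (0.87 log units; beyond the scatter). This step runs the same way as the earlier one for a methyl on a saturated ring carbon, a 7.7-fold higher number from compound 1 to compound 2 (0.89 log units; beyond the scatter), and the two changes together give a 57-fold higher number from compound 1 to compound 4 (1.76 log units; beyond the scatter), so the methylamino to dimethylamino change raises the number on a compound that already carries the ring methyl. Each of these steps rests on single numbers, and compound 3 shows how far apart two entries can lie: the several entries of compound 3 in this assay, 0.8 ug/mL; 15.3 ug/mL (2 entries)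

The compounds shown leave open whether dimethylamino would give a similar rise without the methyl on the saturated ring carbon, so it cannot be said whether the two steps act independently of each other. They also leave open what a longer chain on the amine nitrogen, such as ethyl, or a pyrrolidine ring built around that nitrogen would do, and whether compound 4 would hold its number on repetition.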